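The source may report more compounds than this note shows. Statements on the series, on what has been measured and on what is new or still open speak of the compounds shown alone.

Measured in an in vitro assay on cells for inhibition of Amine oxidase [flavin-containing] A (Homo sapiens), read by fluorescence and spectrophotometry, with a stated time of 20 min; a lower number here means a stronger inhibitor, a higher number a weaker inhibitor: compound 1 `Cn1c(=O)c2c(nc(CSc3cccc(F)c3)n2C)n(C)c1=O` gives 50100 nM; compound 2 `COc1cccc(SCc2nc3c(c(=O)n(C)c(=O)n3C)n2C)c1` gives 41300 nM; compound 3 `Cn1c(=O)c2c(nc(CSc3cccc(Cl)c3)n2C)n(C)c1=O` gives 19400 nM.

Compound 3 stands lowest of the three. The steps to it, a 2.6-fold lower number from compound 1 to compound 3 (0.41 log units; beyond the scatter) and a 2.1-fold lower number from compound 2 to compound 3 (0.33 log units; beyond the scatter), are modest, while a 1.2-fold lower number from compound 1 to compound 2 (0.08 log units; within the scatter) stays within the scatter. Compound 4 `Cn1c(=O)c2c(nc(CSc3ccc(Cl)cc3)n2C)n(C)c1=O` differs from compound 3 in one place: 4-chlorophenyl in place of 3-chlorophenyl on a sulfur. Among the compounds with values here, none of the measured steps bears on this change, as each of them exchanges one group for another at the same spot on the ring rather than shifting a group. With nothing to go on, no step beyond the scatter is expected in this assay for compound 4. Compound 4 is therefore estimated at 19400 nM, with a range of 7000 nM to 55000 nM, an expected step of no change at the digits printed from compound 3 to compound 4 (within the scatter).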

Compound 4, half-maximal inhibitory concentration: 31600 nM
The estimate for compound 4 lay 1.6-fold (0.21 log units) below the measured number; low and high end bracket the measured number.
By their numbers in this assay, from the lowest: compounds 3, 4, 2 and 1 (each within the scatter of the next, the first and the last beyond it).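

In this assay, the first shift of a group around the ring, 4-chlorophenyl in place of 3-chlorophenyl on a sulfur, gives a 1.6-fold higher number from compound 3 to compound 4 (0.21 log units; within the scatter) and so does not separate the two compounds. Compound 3 stood beyond the scatter from the fluoro and methoxy compounds, yet a 1.3-fold lower number from compound 2 to compound 4 (0.12 log units; within the scatter) and a 1.6-fold lower number from compound 1 to compound 4 (0.20 log units; within the scatter) leave compound 4 within the scatter of both. No evidence given here bears on this result. Still open, from the compounds shown here alone, is how an amine or a carboxylic acid on the phenyl ring would read, and whether a longer chain on the sulfur would change the number.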